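Methoxy to hydroxy on a pyrazole pair

The source may report more compounds than this note shows. Statements on the series, on what has been measured and on what is new or still open speak of the compounds shown alone.

In a functional assay on NCI-H522 cells (Homo sapiens) for cytotoxicity, read by sulforhodamine B assay, with a stated time of 48 h, tested at 100 nM (a higher number here means a weaker effect of the compound at the concentration tested, a lower number a stronger effect), compound 2 `COc1cc(C)cc(-c2nn(CC#N)cc2-c2ccnc(-c3ccc(N(C)C)cc3)c2)c1` gives -39%, the second highest of three numbers. Its nearest neighbour is compound 1 `COc1cc(C)cc(-c2c(-c3ccnc(-c4ccc(N(C)C)cc4)c3)cnn2CC#N)c1`, which gives -47%, a number within the scatter of compound 2. The furthest is compound 3 `COc1cc(C)cc(-c2nn(CC#N)cc2-c2ccc(-c3cccc(C(C)=O)c3)nc2)c1`, which gives 68%, a number far higher than compound 2 and beyond the scatter. No single change between two measured compounds is available to calibrate a step.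

Compound 4 `Cc1cc(O)cc(-c2nn(CC#N)cc2-c2ccnc(-c3ccc(N(C)C)cc3)c2)c1` differs from compound 2 in one place: hydrogen in place of methyl on an oxygen on an aromatic ring. The two measured compounds that share the dimethylamino-bearing side of the molecule, compound 1 and compound 2, both give strongly negative numbers, and nothing measured speaks to exchanging the methyl on the oxygen for hydrogen. The step of a number 14 percentage points higher from compound 2 to compound 4 (beyond the scatter) is expected to be small, at most a modest move toward a higher number and quite possibly within the scatter. Compound 4 is therefore estimated at -25%, with a range from -60% to 30%.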

Compound 4, a percentage reported as activity, at one concentration (the size of the read-out at that concentration, not a potency): 75%
Beside the measured number, compound 4's estimate is 100 percentage points below it; measured number outside the range, above it.
By their numbers in this assay, from the lowest: compounds 1 and 2 (each within the scatter of the next); then compounds 3 and 4 (each within the scatter of the next).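

In this assay, the change from methoxy to hydroxy on the aromatic ring proves to be far from a minor edit: losing one methyl from that oxygen gives a number 114 percentage points higher from compound 2 to compound 4 (beyond the scatter) and is the only single-place change shown. The earlier compounds shown here all carried methoxy here, so they could not reveal how sensitive the read-out is to this position. Compound 4 also shows that keeping the dimethylamino-bearing side does not by itself preserve the strongly negative read-out seen with compound 2.

The information available offers no explanation for this step. From the compounds shown here alone, whether an ethoxy group, a fluorine atom or an amine in this place would behave like the methoxy of compound 2 or the hydroxy of compound 4 remains open, as does whether the same change would have a similar effect in compound 1.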